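What a new amide may do to compound 1

The source may hold more compounds than are shown below. What is called first, only, known or untested is meant among the compounds shown, and "the series" means these compounds.

compound 1 `CC(=O)SCCC(CCCCC(=O)O)SC(C)=O` gives 6.04%
compound 2 `O=C(CCCCC(S)CCS)Nc1ccc(F)cc1` gives 18.1%
compound 3 `O=C(CCCCC(S)CCS)Nc1ccc([N+](=O)[O-])c(C(F)(F)F)c1` gives 0.97%

In a functional assay on NCI-H460 cells (Homo sapiens) for inhibition, read by MTT assay, with a stated time of 24 h, tested at 10 ug/mL (a higher number here means more inhibition of growth at the concentration tested, a lower number less inhibition of growth), compound 1 (6.04%) sits within the usual scatter of compound 3 (0.97%), while compound 2 (18.1%) stands beyond the scatter above compound 1.

The unmeasured compound 4 `CC(=O)SCCC(CCCCC(=O)Nc1ccccc1Cl)SC(C)=O` keeps the core of compound 1 and changes it in one place. The change is (2-chlorophenyl)amino in place of hydroxy on a carbonyl carbon and it puts (2-chlorophenyl)amino in place of hydroxy on a carbonyl carbon.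

For the measured compounds named here, no measured pair shows this change on its own. Compound 2 (18.1%) and compound 3 (0.97%) also carry an aromatic ring joined through nitrogen to that carbonyl, but they differ from compound 4 elsewhere and their two values give no single direction. Only a modest rise in this assay is therefore expected, an estimated a number 4 percentage points higher from compound 1 to compound 4 (within the scatter) that may well stay within the scatter.

For compound 4 the estimated value is 10% with an expected range from 0% to 25% in a repeat measurement.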

Compound 4, percent growth inhibition at one concentration: 11.4%
For compound 4 the middle estimate is 1.4 percentage points below the measured one; the measured number falls inside the stated range.
By their numbers in this assay, from the lowest: compounds 3, 1, 4 and 2 (each within the scatter of the next, the first and the last beyond it).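

In this assay, placing (2-chlorophenyl)amino on the carbonyl carbon in place of hydroxy gives a number 5.4 percentage points higher from compound 1 to compound 4 (within the scatter). For the compounds shown here, this is the first direct reading of this change on the core of compound 1: a much larger group with an aromatic ring can take the place of the hydroxy, and the result stays within the usual scatter, so the carboxylic acid is not needed for a reading of this size. Nothing measured here gives a reason for this outcome.

On these data alone, whether the ring or its chlorine counts for more remains open, and a plain phenylamino group at the same carbonyl carbon would help separate the two. As far as these compounds go, it is also open how the (2-chlorophenyl)amino amide would read with free thiol groups in place of the two acetyl-bearing sulfur groups.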